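Swapping the Fluorophenyl Ring for a Pyridyl Ring

The source may report more compounds than this note shows. Statements on the series, on what has been measured and on what is new or still open speak of the compounds shown alone.

Compound 1 `CCCCCN1CCN(c2nc(N)nc3sc(-c4ccc(F)cc4)nc23)CC1` gives > 10000 nM in a functional assay on cells (Lymphocyte, Homo sapiens); on this read-out lower numbers stand for stronger inhibition and higher numbers for weaker inhibition; this is a limit of the assay, not a number.
Compound 2 `Nc1nc(N2CCN(C(=O)COc3ccc(F)cc3)CC2)c2nc(-c3ccc(F)cc3)sc2n1` gives 70 nM in this assay.
Compound 3 `Nc1nc(N2CCN(C(=O)COc3ccc(Br)cc3)CC2)c2nc(-c3ccc(F)cc3)sc2n1` gives 380 nM in this assay.

Compound 2 holds the lowest of the two numbers, and compound 3 sits a 5.4-fold higher number from compound 2 to compound 3 (0.73 log units; beyond the scatter). The unmeasured compound 4 `Nc1nc(N2CCN(C(=O)COc3ccc(F)cc3)CC2)c2nc(-c3cccnc3)sc2n1` differs from compound 2 in one place: pyridin-3-yl in place of 4-fluorophenyl on an aromatic carbon. For the measured compounds named here, none of the measured steps touch this ring: an at least 140-fold lower number from compound 1 to compound 2 (2.15 log units; beyond the scatter) and an at least 26-fold lower number from compound 1 to compound 3 (1.42 log units; beyond the scatter) change the group on the ring nitrogen, while a 5.4-fold higher number from compound 2 to compound 3 (0.73 log units; beyond the scatter) changes the halogen on the phenoxy ring. Going by the values given here, no measured step therefore bears on this change, and the expectation rests on the swap alone. The expected step is a 2.1-fold higher number from compound 2 to compound 4 (0.33 log units; beyond the scatter). Compound 4 is estimated at 150 nM, expected to fall between 40 nM and 600 nM.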

Compound 4, half-maximal inhibitory concentration: 12 nM
Compound 4: middle estimate off by 13-fold (1.10 log units), on the high side, and the stated range ends above it.
By their numbers in this assay, from the lowest: compound 4; then compound 2; then compound 3. At a limit, above all of these: compound 1.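

In this assay, this aromatic carbon of the five-membered ring proves to be a place where the number can still fall: a 5.8-fold lower number from compound 2 to compound 4 (0.77 log units; beyond the scatter). The 4-fluorophenyl group is therefore not required here, and pyridin-3-yl, which adds one hydrogen-bond acceptor to the ring, does better in its place. Nothing among the data shown explains this gain. On these data alone, it remains open whether the ring nitrogen's location matters, as pyridin-2-yl or pyridin-4-yl would test. Plain phenyl would also show whether removing the fluorine alone accounts for any of the change.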